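The source may hold more compounds than are shown below. What is called first, only, known or untested is meant among the compounds shown, and "the series" means these compounds.

Measured compounds: compound 1 `COc1cc2ncnc(Nc3ccc(NC(=O)c4ccccc4C)cc3)c2cc1OC` with 21000 nM; compound 2 `COc1cc2ncnc(Nc3ccc(NC(=O)c4c(F)cccc4F)cc3)c2cc1OC` with 24000 nM.

In a functional assay on MCF7 cells (Homo sapiens) for inhibition, read by MTT assay (a higher number here means a weaker inhibitor, a lower number a stronger inhibitor), compound 1 gives 21000 nM, the lowest of the two numbers, and the step of a 1.1-fold higher number from compound 1 to compound 2 (0.06 log units; within the scatter) stays within the scatter. Compound 3 `COc1cc2ncnc(Nc3ccc(NC(=O)c4cc(F)ccc4Br)cc3)c2cc1OC` differs from compound 1 by 2-bromo-5-fluorophenyl in place of 2-methylphenyl on a carbonyl carbon. Going by the values given here, the only measured step that bears on this change is a 1.1-fold higher number from compound 1 to compound 2 (0.06 log units; within the scatter), where another substituted phenyl replaced the same 2-methylphenyl on the carbonyl carbon and the number hardly moved. A step of a 1.0-fold higher number from compound 1 to compound 3 (0.02 log units; within the scatter) is therefore expected, with no shift beyond the scatter. Compound 3 is estimated at 22000 nM, expected between 10000 nM and 48000 nM.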

Compound 3, half-maximal inhibitory concentration: 26000 nM
The estimate for compound 3 lay 1.2-fold (0.07 log units) below the measured number; the range from low to high includes it.
By their numbers in this assay, from the lowest: compounds 1, 2 and 3 (each within the scatter of the next).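

In this assay the step of a 1.2-fold higher number from compound 1 to compound 3 (0.09 log units; within the scatter) and the step of a 1.1-fold higher number from compound 2 to compound 3 (0.03 log units; within the scatter) both stay within the scatter, so 2-bromo-5-fluorophenyl reads like the two earlier groups on this carbonyl carbon. The exchange now holds for a group carrying bromine and fluorine together, and compound 1, compound 2 and compound 3 cannot be ordered. Nothing available offers a reason for this flat result. Open, on these data alone, is whether a pyridine ring, a carboxylic acid or a longer alkyl chain in place of the phenyl on this carbonyl carbon would move the number beyond the scatter.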